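The source may report more compounds than this note shows. Statements on the series, on what has been measured and on what is new or still open speak of the compounds shown alone.

Measured in a functional assay on PC-3 cells (Homo sapiens) for antiproliferative activity, read by MTT assay, with a stated time of 48 h; a higher number here means a weaker inhibitor, a lower number a stronger inhibitor:
- compound 1 `CCn1c(C(=O)NCCN(C)C)ccc1C(CC)(CC)c1ccc(OCCC(O)(CC)CC)c(C)c1`: 870 nM
- compound 2 `CCn1c(C(=O)NCCN)ccc1C(CC)(CC)c1ccc(OCCC(O)(CC)CC)c(C)c1`: 2420 nM
- compound 3 `CCn1c(C(=O)Nc2ccc(OC(F)(F)F)cc2)ccc1C(CC)(CC)c1ccc(OCCC(O)(CC)CC)c(C)c1`: > 50000 nM (a limit, not a number)

Compound 3 stands at the limit of > 50000 nM in this assay, at which 1 of the 3 values shown sits, so the series gives no true value for it.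

The next structure is compound 4 `CCn1c(C(=O)N(C)CC(=O)O)ccc1C(CC)(CC)c1ccc(OCCC(O)(CC)CC)c(C)c1`, and the change to it is (carboxymethyl)(methyl)amino in place of (4-(trifluoromethoxy)phenyl)amino on a carbonyl carbon.

Going by the values given here, two measured steps bear most directly on this, an at least 57-fold higher number from compound 1 to compound 3 (1.75 log units; beyond the scatter) and an at least 20-fold higher number from compound 2 to compound 3 (1.31 log units; beyond the scatter). Both are large, and both involve the same 4-(trifluoromethoxy)phenyl group that compound 4 lacks. Read in reverse, they point to a lower number once that group leaves. The read-across is only partial, as neither compound 1 nor compound 2 carries the carboxymethyl group. The step of a 2.8-fold higher number from compound 1 to compound 2 (0.44 log units; beyond the scatter) also shows that the chain end matters in this assay.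

The expected change is an at least 4.1-fold lower number from compound 3 to compound 4 (0.61 log units; beyond the scatter), a move towards a lower number, though smaller than the two large steps, and compound 4 may yet remain at the limit. Compound 4 is estimated at 12000 nM, with an expected range from 2500 nM to 50000 nM.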

Compound 4, half-maximal inhibitory concentration: 2250 nM
For compound 4 the middle estimate is 5.3-fold (0.73 log units) above the measured one; measured number below the stated range.
By their numbers in this assay, from the lowest: compound 1; then compounds 4 and 2 (each within the scatter of the next). At a limit, above all of these: compound 3.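

Compound 3 carries a limit, not a number: the limit of > 50000 nM in this assay, at which 1 of the 4 values shown sits.

In this assay, (carboxymethyl)(methyl)amino in place of (4-(trifluoromethoxy)phenyl)amino on the carbonyl carbon gives an at least 22-fold lower number from compound 3 to compound 4 (1.34 log units; beyond the scatter), so a measured value at this position does not depend on an amine at the chain end. Compound 4 has a carboxylic acid at that end, and its comparisons with the two amine-ended compounds read a 1.1-fold lower number from compound 2 to compound 4 (0.03 log units; within the scatter) and a 2.6-fold higher number from compound 1 to compound 4 (0.41 log units; beyond the scatter), so only the dimethylamino compound stays apart from it.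

On these data alone, whether the limit of compound 3 follows the phenyl ring or the trifluoromethoxy group stays open, and a plain phenyl amide would separate the two. As far as these compounds go, the part played by the methyl on the amide nitrogen of compound 4 also stays open, and a carboxymethyl amide that keeps the amide hydrogen would address it.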